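What a Nitro Group May Do to Compound 3

The source may report more compounds than this note shows. Statements on the series, on what has been measured and on what is new or still open speak of the compounds shown alone.

In a functional assay on SGC-7901 cells (Homo sapiens) for antiproliferative activity, read by MTT assay, with a stated time of 72 h (a lower number here means a stronger inhibitor, a higher number a weaker inhibitor), compound 1 `CCOC(=O)c1cc(-c2ccc(OC)cc2)c(-c2cc(OC)c(OC)c(OC)c2)s1` gives 6820 nM, and compound 3 `COc1ccc(-c2cc(C(=O)O)sc2-c2cc(OC)c(OC)c(OC)c2)cc1` gives 4220 nM. These two differ by hydrogen in place of ethyl on an oxygen next to a carbonyl group, and a 1.6-fold lower number from compound 1 to compound 3 (0.21 log units; within the scatter), so the pair stands level. Compound 2 `CCOC(=O)c1cc(-c2ccc(OC)c([N+](=O)[O-])c2)c(-c2cc(OC)c(OC)c(OC)c2)s1` gives 19400 nM, a higher number than either of them. Compound 3 therefore shares the low end of these three numbers with compound 1.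

Compound 4 `COc1ccc(-c2cc(C(=O)O)sc2-c2cc(OC)c(OC)c(OC)c2)cc1[N+](=O)[O-]` differs from compound 3 by a single change: nitro in place of hydrogen on an aromatic carbon. This is nitro in place of hydrogen on an aromatic carbon, ortho to a methoxy group. The same swap has been measured only once, on compound 1, and there the data show a 2.8-fold higher number from compound 1 to compound 2 (0.45 log units; beyond the scatter), a modest step beyond the scatter. The level result for a 1.6-fold lower number from compound 1 to compound 3 (0.21 log units; within the scatter) gives some ground to expect that compound 3 will respond in a similar way, though a single example is thin support. The expected result is a 2.7-fold higher number from compound 3 to compound 4 (0.44 log units; beyond the scatter), a modest step towards a higher number. For compound 4 the estimated value in this assay is 11500 nM, with an expected range from 5000 nM to 26000 nM.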

Compound 4, half-maximal inhibitory concentration: 21600 nM
For compound 4 the middle estimate is 1.9-fold (0.27 log units) below the measured one; low and high end bracket the measured number.
By their numbers in this assay, from the lowest: compounds 3 and 1 (each within the scatter of the next); then compounds 2 and 4 (each within the scatter of the next).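

Nitro in place of hydrogen on this aromatic carbon, ortho to a methoxy group, now gives a rise on a second core (a 5.1-fold higher number from compound 3 to compound 4 (0.71 log units; beyond the scatter)), so the rise seen on compound 1 no longer stands alone in this assay. Both steps go the same way and lie beyond the scatter, and their sizes cannot be told apart: the same change on two cores in this assay, a 2.8-fold higher number (0.45 log units; beyond the scatter) from compound 1 to compound 2 and a 5.1-fold higher number (0.71 log units; beyond the scatter) from compound 3 to compound 4, 1.8-fold (0.26 log units) apart, within the scatter of two such steps. Hydrogen in place of ethyl on the oxygen next to the carbonyl group leaves the number level even with the nitro group present (a 1.1-fold higher number from compound 2 to compound 4 (0.05 log units; within the scatter)), so in these four compounds the nitro change and the ethyl change appear to act independently: the same change on two cores in this assay, a 1.6-fold lower number (0.21 log units; within the scatter) from compound 1 to compound 3 and a 1.1-fold higher number (0.05 log units; within the scatter) from compound 2 to compound 4, 1.8-fold (0.26 log units) apart, within the scatter of two such steps.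

The compounds shown leave open whether the rise belongs to nitro itself or would also follow an amine, a chlorine or a methyl group on the same aromatic carbon. They also leave open why the number rises, since a rise in this cell assay says nothing by itself about how the change acts on the cells.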